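From 4-nitrophenyl to 3-ethylphenyl on the shared core

A few compounds are considered here, and "the series" means these few. Any claim that something is new, unique, unknown or untested is made for them only; others in the source may bear on it.

In an ADME assay on BJ cells (Homo sapiens) for cytotoxicity, with a stated time of 72 h (on this read-out lower numbers stand for an effect already at smaller amounts and higher numbers for an effect only at larger amounts of compound), compound 1 (`Cc1nn(-c2ccccc2)c2nc(-c3ccc(C#N)cc3)c(C#N)c(-c3ccccc3O)c12`) gives > 20000 nM, which is a limit of the assay and not a number. Compound 2 (`Cc1nn(-c2ccccc2)c2nc(-c3ccc([N+](=O)[O-])cc3)c(C#N)c(-c3ccccc3O)c12`) gives > 20000 nM, which is likewise only a limit. Compound 2 therefore has no readable position of its own, and the whole evidence so far is the limit of > 20000 nM in this assay, at which 2 of the 2 values shown sit. Going by the values given here, the only measured step is a step that the two limits leave unreadable from compound 1 to compound 2, so it gives no size to carry forward, although it does involve the aryl group now being replaced.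

Compound 3 (`CCc1cccc(-c2nc3c(c(C)nn3-c3ccccc3)c(-c3ccccc3O)c2C#N)c1`) has 3-ethylphenyl in place of 4-nitrophenyl on an aromatic carbon, next to the ring nitrogen and ortho to a cyano group (3-ethylphenyl in place of 4-nitrophenyl on an aromatic carbon). With no readable step available, no direction can be taken from the data, and no shift beyond the scatter is expected in this assay. The estimated step is a number no higher from compound 2 to compound 3 (the limit leaves the size open). A further limit result is the most likely outcome. For compound 3 the expected value is 20000 nM, with an estimated range of 8000 nM to 40000 nM.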

Compound 3, half-maximal effective concentration: > 20000 nM
Compound 3: only a limit was reported; the forecaster's own chance of this, stated with the estimate: 70%; the middle value sits exactly at the limit.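

In this assay compound 3 gives > 20000 nM, which is a limit and not a number. The steps joining compound 3 to compound 1 and compound 2 cannot be read, and the evidence remains: the limit of > 20000 nM in this assay, at which 3 of the 3 values shown sit. The compounds shown leave open whether exchanging this aryl group shifts the read-out at all.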